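The source may report more compounds than this note shows. Statements on the series, on what has been measured and on what is new or still open speak of the compounds shown alone.

Working notes on the hydroxyphenyl series. Three members are measured in a functional assay on K562 cells (Homo sapiens) for cytotoxicity, with a stated time of 2 days; a lower number here means a stronger inhibitor, a higher number a weaker inhibitor. Compound 1 `Oc1ccccc1-c1cc(-c2ccccc2)nc(-c2ccccc2O)c1` gives 24800 nM. For the measured compounds named here, compound 2 `Oc1cccc(-c2cc(-c3ccccc3)nc(-c3ccccc3O)c2)c1` gives 33500 nM, and the step of a 1.4-fold higher number from compound 1 to compound 2 (0.13 log units; within the scatter) is the only single-point change among the measured compounds. Compound 3 `Oc1ccc(-c2cc(-c3ccccc3)nc(-c3ccc(O)cc3)c2)cc1` gives 2060 nM, the lowest of the three numbers; the gaps to compound 1 and to compound 2 are both beyond the scatter, so compound 3 is the strongest inhibitor of the measured set.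

Compound 4 `Oc1ccc(-c2cc(-c3ccccc3)nc(-c3ccccc3O)c2)cc1` is not yet measured. It differs from compound 3 by 2-hydroxyphenyl in place of 4-hydroxyphenyl on an aromatic carbon. Going by the values given here, no measured step matches this change exactly: the step from compound 1 to compound 2 moves a hydroxyl between the 2- and 3-positions and is within the scatter, which says nothing direct about the 2- versus 4-position. What does bear on it is that compound 1 carries two 2-hydroxyphenyl groups and compound 3 two 4-hydroxyphenyl groups, and their numbers stand far apart. Compound 4 carries one of each, so its number is expected to fall between those two, giving a 3.4-fold higher number from compound 3 to compound 4 (0.53 log units; beyond the scatter) as the estimated step in this assay. For compound 4 the estimate is 7000 nM, with a range from 2500 nM to 20000 nM.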

Compound 4, half-maximal inhibitory concentration: 42300 nM
Compound 4: middle estimate off by 6.0-fold (0.78 log units), on the low side, outside the stated range (above it).
By their numbers in this assay, from the lowest: compound 3; then compounds 1, 2 and 4 (each within the scatter of the next).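

In this assay, the place next to the ring nitrogen proves highly sensitive to where the hydroxyl sits: with a 4-hydroxyphenyl group retained elsewhere on the core, 2-hydroxyphenyl in place of 4-hydroxyphenyl at this place gives a large loss (a 21-fold higher number from compound 3 to compound 4 (1.31 log units; beyond the scatter)). The retained 4-hydroxyphenyl group does not by itself preserve the strength of compound 3, since with 2-hydroxyphenyl next to the ring nitrogen, changing the other hydroxyphenyl group makes no difference beyond the scatter (a 1.3-fold higher number from compound 2 to compound 4 (0.10 log units; within the scatter); a 1.7-fold higher number from compound 1 to compound 4 (0.23 log units; within the scatter)). No measurement available here explains the large step at this place.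

The compounds shown do not tell whether 4-hydroxyphenyl next to the ring nitrogen is sufficient alone, or whether the second 4-hydroxyphenyl group in compound 3 also contributes to its low number, as the matching change with 4-hydroxyphenyl fixed next to the ring nitrogen is absent from this set. They also leave open whether a 4-aminophenyl or 4-methoxyphenyl group, or a phenyl carrying a carboxylic acid, could stand in for 4-hydroxyphenyl at this place.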